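The compounds below may be only part of what the source reports. "The series", "measured", "known", "first", "only" and "open" are said of these compounds alone.

Measured compounds:
compound 1, `O=C(/C=C/c1cccnc1)c1nc2ccccc2[nH]1`: 15300 nM
compound 2, `O=C(/C=C/c1ccccc1Br)c1nc2ccccc2[nH]1`: 16400 nM
compound 3, `O=C(CCc1ccccn1)c1nc2ccccc2[nH]1`: reported only as a limit, > 100000 nM

All three share one core and were tested in a functional assay on HCT-116 cells (Homo sapiens) for antiproliferative activity, read by MTT assay, with a stated time of 48 h; a lower number here means a stronger inhibitor, a higher number a weaker inhibitor. Compound 1 gives 15300 nM in this assay, the lowest of the two numbers that were actually reached, and compound 2 sits so close to it, at 16400 nM, that the two cannot be told apart within the usual scatter. For compound 3 this assay reports no number at all but only a limit, > 100000 nM; that is the situation described by the limit of > 100000 nM in this assay, at which 1 of the 3 values shown sits.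

The next compound, compound 4 with structure `O=C(/C=C/c1ccncc1)c1nc2ccccc2[nH]1`, is not yet measured. It keeps every atom of compound 1 but joins them differently: pyridin-4-yl in place of pyridin-3-yl on a double-bonded chain carbon bound to a double-bonded chain carbon. Going by the values given here, no measured pair shows what this particular swap does, so the expectation rests on compound 1 alone. Because compound 1 gives 15300 nM in this assay and the group that leaves and the group that enters are counted identically, only moving the single ring nitrogen, the step from compound 1 to compound 4 is expected to be small, and most likely not beyond the scatter in this assay. The estimated step is a 1.2-fold lower number from compound 1 to compound 4 (0.07 log units; within the scatter). Compound 4 is therefore expected to give about 13000 nM in this assay, in a range from 5000 nM to 35000 nM.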

Compound 4, half-maximal inhibitory concentration: 710 nM
Beside the measured number, compound 4's estimate is 18-fold (1.26 log units) above it; the measured number lies below the stated range.
By their numbers in this assay, from the lowest: compound 4; then compounds 1 and 2 (each within the scatter of the next). At a limit, above all of these: compound 3.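

Moving the single ring nitrogen, with pyridin-4-yl in place of pyridin-3-yl on a double-bonded chain carbon bound to a double-bonded chain carbon, gives in this assay a 22-fold lower number from compound 1 to compound 4 (1.33 log units; beyond the scatter), the first step shown between two measured compounds that differ in one place. This step shows that the site on the double-bonded chain is sensitive to where the nitrogen lies within the ring, even though the leaving and entering groups have the same heavy atoms, the same ring size and the same count of hydrogen-bond acceptors, so counts like these are a poor guide to potency at this site. The step itself is a measured fact, but nothing shown here gives a reason for its size.

The compounds shown leave open whether the gain is specific to pyridin-4-yl, since a pyridin-2-yl group on the same double-bonded chain, or a phenyl ring carrying an amine or a carboxylic acid in place of the pyridine, would test how narrow the preference is. They also leave open whether pyridin-4-yl would give a similar step when placed on a longer chain or on a core carrying further groups.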